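Solubility notes: methoxy added to compound 1

This account rests on a few compounds, and the source may have more. Where it says the series, first, only, none or still open, it means among the compounds named here.

Compound 1 `CN(C)c1ccc(Nc2c(NCCCCCC(=O)NO)c(=O)c2=O)cc1` gives 12000000 nM
Compound 2 `COc1ccc(Nc2c(NCCCCCC(=O)NO)c(=O)c2=O)cc1` gives 3300000 nM

Compound 1 holds the higher of the two numbers in a physicochemical assay for solubility, read by HPLC, in phosphate buffer, with a stated time of 24 h, at pH 7.4, tested at 100 uM (on this read-out lower numbers stand for lower solubility and higher numbers for higher solubility), so far. In compound 3 `COc1cc(Nc2c(NCCCCCC(=O)NO)c(=O)c2=O)ccc1N(C)C` the core of compound 1 changes by methoxy in place of hydrogen on an aromatic carbon and so gains methoxy in place of hydrogen on an aromatic carbon, ortho to a dimethylamino group. Within the data shown here, the only measured step is a 3.6-fold lower number from compound 1 to compound 2 (0.56 log units; beyond the scatter) and it is modest. That step removes dimethylamino, which compound 3 keeps, so it bears only loosely. A small downward step in this assay is expected, perhaps none beyond the scatter. An estimated 1.5-fold lower number from compound 1 to compound 3 (0.18 log units; within the scatter) is expected. In this assay compound 3 is estimated at 8000000 nM with an expected range of 3000000 nM to 18000000 nM overall.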

Compound 3, solubility: 93000000 nM
Compound 3: middle estimate off by 12-fold (1.07 log units), on the low side; the whole stated range lies below it.
By their numbers in this assay, from the lowest: compound 2; then compound 1; then compound 3.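

Methoxy in place of hydrogen, ortho to a dimethylamino group, gives a 7.8-fold higher number from compound 1 to compound 3 (0.89 log units; beyond the scatter) in this assay and so shows that this position on the core of compound 1 can raise the read-out beyond the scatter. The earlier step ran downward and involved a different change, methoxy in place of dimethylamino. No measurement on hand accounts for the rise.

Still open, from the compounds shown here alone, is whether a hydroxyl group or fluorine at this position moves the number the same way. Also open, going by these compounds, is whether the rise persists when a primary amine replaces dimethylamino.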